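Swapping a Methylphenyl for a Thiophene Ring

The source may report more compounds than this note shows. Statements on the series, on what has been measured and on what is new or still open speak of the compounds shown alone.

Measured so far in a functional assay on CHO cells for agonist activity at Alpha-2C adrenergic receptor (Homo sapiens); on this read-out higher numbers stand for an effect only at larger amounts of compound and lower numbers for an effect already at smaller amounts: compound 1 `CC(Oc1ccccc1-c1cccnc1)C1=NCCN1` gives 50.1 nM; compound 2 `Cc1ccccc1-c1ccccc1OC(C)C1=NCCN1` gives 363 nM; compound 3 `Cc1cccc(-c2ccccc2OC(C)C2=NCCN2)c1` gives 1580 nM.

Compound 3 shows the highest number of the three, with steps of a 4.4-fold higher number from compound 2 to compound 3 (0.64 log units; beyond the scatter) and a 32-fold higher number from compound 1 to compound 3 (1.50 log units; beyond the scatter). Compound 4 `CC(Oc1ccccc1-c1cccs1)C1=NCCN1` differs from compound 3 by thiophen-2-yl in place of 3-methylphenyl on an aromatic carbon. Among the measured compounds shown here, the relevant step is the one from compound 1, whose pyridin-3-yl also carries a hetero atom in its aromatic ring, to compound 3: a 32-fold higher number from compound 1 to compound 3 (1.50 log units; beyond the scatter). That step ran in the opposite direction to the present one, so a large drop in this assay is expected for compound 4. Compound 4 is estimated at 80 nM (range 20 nM to 400 nM), an expected step of a 20-fold lower number from compound 3 to compound 4 (1.30 log units; beyond the scatter).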

Compound 4, half-maximal effective concentration: 58.9 nM
Compound 4: middle estimate off by 1.4-fold (0.13 log units), on the high side; measured number inside the range.
By their numbers in this assay, from the lowest: compounds 1 and 4 (each within the scatter of the next); then compound 2; then compound 3.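

In this assay thiophen-2-yl on this aromatic carbon gives a 27-fold lower number from compound 3 to compound 4 (1.43 log units; beyond the scatter) and a 6.2-fold lower number from compound 2 to compound 4 (0.79 log units; beyond the scatter), so this five-membered ring with sulfur stands well below both methylphenyl rings. Against pyridin-3-yl it gives a 1.2-fold higher number from compound 1 to compound 4 (0.07 log units; within the scatter), so these two rings, one six-membered and one five-membered, each with a hetero atom, cannot be told apart here. No available measurement explains these differences. Open, on these data alone, is whether plain phenyl, thiophen-3-yl or a pyridine ring carrying an amine would give a similarly low number.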